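Glucagon receptor series: cyclopropyl to cyclobutyl at the ether carbon

A few compounds are considered here, and "the series" means these few. Any claim that something is new, unique, unknown or untested is made for them only; others in the source may bear on it.

Measured compounds:
compound 1 `O=C(O)CCNC(=O)c1ccc(C(Oc2ccc(-n3cc(C(F)(F)F)cn3)cc2)C2CC2)cc1` with 1300 nM
compound 2 `CCCC(Oc1ccc(-n2cccn2)cc1)c1ccc(C(=O)NCCC(=O)O)cc1` with 4100 nM
compound 3 `CCCC(Oc1cnc(-n2cc(C(F)(F)F)cn2)nc1)c1ccc(C(=O)NCCC(=O)O)cc1` with 1100 nM

Three compounds of the shared core have been run in an assay on cells for displacement of a labelled ligand from Glucagon receptor (Homo sapiens), in the presence of a further agent that is not named here; a lower number here means a stronger inhibitor, a higher number a weaker inhibitor. Compound 1 stands second highest of the three numbers. Its nearest neighbour is compound 3, whose value lies within the scatter of that of compound 1, so no order between the two can be read. The furthest is compound 2, whose value lies beyond the scatter above that of compound 1; compound 2 differs from compound 1 in more than one place, so the gap is noted without a cause.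

Compound 4 `O=C(O)CCNC(=O)c1ccc(C(Oc2ccc(-n3cc(C(F)(F)F)cn3)cc2)C2CCC2)cc1` is not yet measured. It differs from compound 1 in a single place: cyclobutyl in place of cyclopropyl on a saturated chain carbon bound to an aromatic carbon and an oxygen on an aromatic ring. Going by the values given here, no measured pair in this set carries the same change, so the expectation rests on the size of the change alone. A step of one carbon in a saturated ring is expected to move the number little, most likely not beyond the scatter, with a slight lean toward a lower number.

For compound 4 the estimate in this assay is 1000 nM, in the range 400 nM to 2600 nM, which means an expected step of a 1.3-fold lower number from compound 1 to compound 4 (0.11 log units; within the scatter).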

Compound 4, inhibition constant: 700 nM
Compound 4: the middle estimate sits 1.4-fold (0.15 log units) above what was measured, and the stated range covers the measured number.
By their numbers in this assay, from the lowest: compounds 4, 3 and 1 (each within the scatter of the next); then compound 2.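

Going by these compounds alone, the step of a 1.9-fold lower number from compound 1 to compound 4 (0.27 log units; within the scatter) in this assay is the first comparison that changes only the group on a saturated chain carbon bound to an aromatic carbon and an oxygen on an aromatic ring. It lies within the scatter, so no order can be read between cyclopropyl and cyclobutyl, and this single pair shows that a four-membered ring of carbon can stand here in place of a three-membered one without a change beyond the scatter. No supporting data accompany the pair, so the result remains an observation without an assigned cause.

Still open, on these data alone, is whether a larger ring of carbon, such as cyclopentyl, or a branched chain, such as tert-butyl, at this carbon would give a step beyond the scatter on the core of compound 1. The compounds shown also leave the propyl chain unresolved against these rings, as compound 2 and compound 3 each differ from compound 1 in more than one place.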